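Swapping an ether oxygen for a bare carbon on compound 1

The source may report more compounds than this note shows. Statements on the series, on what has been measured and on what is new or still open speak of the compounds shown alone.

Measured in an assay on CHO cells with Alpha-2C adrenergic receptor (Homo sapiens) as the target; on this read-out lower numbers stand for smaller maximal responses and higher numbers for larger maximal responses:
- compound 1, `CCOc1ccccc1OC(C)C1=NCCN1`, gives 0.45
- compound 2, `CC(Oc1ccccc1OC1CC1)C1=NCCN1`, gives 0.7
- compound 3, `COc1ccccc1OC(C)C1=NCCN1`, gives 0.6

Compound 1 has the lowest of the three numbers: compound 3 sits nearest to it, and compound 2 furthest away. Compound 4, `CCc1ccccc1OC(C)C1=NCCN1`, is not yet measured. It differs from compound 1 in one place: ethyl in place of ethoxy on an aromatic carbon. The oxygen that carried the ethyl group is gone, and the ethyl sits directly on the ring.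

Among the measured compounds shown here, no measured step removes that oxygen, so none bears on this change directly. The two steps that start from compound 1 both alter what hangs on that oxygen: a number 0.25 higher from compound 1 to compound 2 (beyond the scatter) and a number 0.15 higher from compound 1 to compound 3 (beyond the scatter). Both move the number upward by a modest amount, while a number 0.10 lower from compound 2 to compound 3 (within the scatter) shows that the two larger groups there differ little from each other. Changes at this position, then, have so far shifted the response modestly, and always upward from compound 1, though losing the oxygen is a different kind of change from trimming or enlarging the group on it.

Compound 4 is therefore expected to land around 0.55, within 0.35 to 0.75, a step a number 0.10 higher from compound 1 to compound 4 (within the scatter) that is estimated to stay within the scatter.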

Compound 4, intrinsic activity: the largest response reached, as a fraction of the reference agonist's: 0.6
Compound 4: middle estimate off by 0.050, on the low side; low and high end bracket the measured number.
By their numbers in this assay, from the lowest: compound 1; then compounds 3, 4 and 2 (each within the scatter of the next).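

Among the compounds shown here, the ether oxygen on this aromatic carbon is not required for a sizeable response in this assay: ethyl in place of ethoxy gives a number 0.15 higher from compound 1 to compound 4 (beyond the scatter) and keeps the same two-carbon group while removing the oxygen, so this is the first look at a change of the atom joining the group to the ring. Comparison with the other oxygen-linked groups shows no separation, with no change at the digits printed from compound 3 to compound 4 (within the scatter) for ethyl in place of methoxy and a number 0.10 lower from compound 2 to compound 4 (within the scatter) for ethyl in place of cyclopropyloxy, which means that ethyl, methoxy and cyclopropyloxy cannot be told apart here, while ethoxy alone sits lower. Nothing available explains why ethoxy stands apart from the other three groups.

For the compounds shown here, with ethyl as the only group attached without an oxygen, it remains open whether the response holds for a methyl, a cyclopropyl or a longer chain such as butyl on the same aromatic carbon. As far as these compounds go, it is equally open how an amine or a carboxylic acid there would change the maximal response in this assay.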